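The compounds below may be only part of what the source reports. "The series", "measured", "known", "first", "only" and "open" are said of these compounds alone.

Going by the values given here, in a functional assay on A549 cells (Homo sapiens) for inhibition, read by CCK-8 assay, with a stated time of 48 h (on this read-out higher numbers stand for weaker inhibition and lower numbers for stronger inhibition), compound 2 `O=C(NC(=S)Nc1ccc(F)cc1)c1cn(-c2ccccc2)nc1-c1ccccc1` gives 3500 nM, the highest of the three numbers so far, though both other values sit within the scatter of it. Compound 1 `Cc1ccc(-c2nn(-c3ccccc3)cc2C(=O)NC(=S)Nc2ccc(Cl)cc2)cc1` gives 3170 nM and compound 3 `Cc1ccc(NC(=S)NC(=O)c2cn(-c3ccccc3)nc2-c2ccccc2)cc1` gives 2800 nM. Among the compounds with values here, the single one-place step measured is a 1.3-fold lower number from compound 2 to compound 3 (0.10 log units; within the scatter), on the ring that carries the thiourea nitrogen. Compound 4 `O=C(NC(=S)Nc1ccc(F)cc1)c1cn(-c2ccccc2)nc1-c1ccc(F)cc1` differs from compound 2 by fluoro in place of hydrogen on an aromatic carbon, on the other phenyl ring. Within the data shown here, no measured step probes that ring on its own; the one measured change elsewhere stayed within the scatter, so in this assay no step beyond the scatter is expected for compound 4. Compound 4 is therefore estimated at 3400 nM (range 1500 nM to 7500 nM), an expected step of a 1.0-fold lower number from compound 2 to compound 4 (0.01 log units; within the scatter).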

Compound 4, half-maximal inhibitory concentration: 3540 nM
Estimate against measurement, compound 4: 1.0-fold (0.02 log units) below; the measured number falls inside the stated range.
By their numbers in this assay, from the lowest: compounds 3, 1, 2 and 4 (each within the scatter of the next).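

Phenyl to 4-fluorophenyl gives a 1.0-fold higher number from compound 2 to compound 4 (0.00 log units; within the scatter) in this assay, the first reading on this ring in a compound pair that differs in one place. At this position, para to a large group, fluoro in place of hydrogen therefore produces no step beyond the scatter. No available evidence bears on this result.

A single small substituent is all that this pair tests at this position. From the compounds shown here alone, whether an amine, a carboxylic acid or a longer chain there would give a step beyond the scatter remains open.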